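The source may report more compounds than this note shows. Statements on the series, on what has been measured and on what is new or still open speak of the compounds shown alone.

In a functional assay on MDA-MB-231 cells (Homo sapiens) for cytotoxicity, read by MTT assay, with a stated time of 72 h (a lower number here means a stronger inhibitor, a higher number a weaker inhibitor), compound 1 `Nc1ccccc1NC(=O)c1ccc(NC(=S)NCc2ccc(Cl)nc2)cc1` gives 42000 nM, a weak result on this scale. Compound 2 `Nc1ccccc1NC(=O)c1ccc(NC(=O)NCc2cccnc2)cc1` gives > 100000 nM, which is a limit of the assay and not a number. Compound 2 therefore has no exact place on the scale, and the limit of > 100000 nM in this assay, at which 1 of the 2 values shown sits, marks where it stands.

Compound 3 `Nc1ccc(CNC(=O)Nc2ccc(C(=O)Nc3ccccc3N)cc2)cn1` differs from compound 2 in one place: amino in place of hydrogen on an aromatic carbon. Amino replaces hydrogen on an aromatic carbon, next to the ring nitrogen and para to a large group, so that pyridin-3-yl becomes 6-aminopyridin-3-yl.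

Among the compounds with values here, no measured pair here shows what this kind of change does, so any forecast is loose. A modest step towards stronger inhibition in this assay is expected, and a result that again reaches the limit would be no surprise. The nearest real number is that of compound 1 at 42000 nM, so the expectation stays in this weak range. The expected change is an at least 1.6-fold lower number from compound 2 to compound 3 (0.22 log units; that floor lies within the scatter). For compound 3 the estimated value is 60000 nM, with an expected range of 25000 nM to 100000 nM.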

Compound 3, half-maximal inhibitory concentration: > 100000 nM
Compound 3: a limit, no number (the forecaster's own chance of this, stated with the estimate: 45%); at least 1.6-fold (0.22 log units) between middle value and limit.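

In this assay compound 3 gives > 100000 nM and this is a limit of the assay, not a number. Compound 2 also stands at a limit, so no step can be read between compound 2 and compound 3: the limit of > 100000 nM in this assay, at which 2 of the 3 values shown sit.

The compounds shown leave open whether amino in place of hydrogen on an aromatic carbon changes the result at all.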